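Tetradecyl and octadecyl sulfonamide amides against a colon carcinoma line

The compounds below may be only part of what the source reports. "The series", "measured", "known", "first", "only" and "open" are said of these compounds alone.

Four compounds share one core, an amide of a sulfonylated threonine-type unit carrying a long saturated chain. Compound 1 `CCCCCCCCCCCCCCNC(=O)[C@@H](NS(=O)(=O)c1ccc(C)cc1)[C@@H](C)O`, compound 2 `CCCCCCCCCCCCCCNC(=O)[C@@H](NS(=O)(=O)c1cccs1)[C@@H](C)O` and compound 3 `CCCCCCCCCCCCCCCCCCNC(=O)[C@@H](NS(=O)(=O)c1ccc(C)cc1)[C@@H](C)O` have been measured; compound 4 `CCCCCCCCCCCCCCCCCCNC(=O)[C@@H](NS(=O)(=O)c1cccs1)[C@@H](C)O` has not.

In a functional assay on SW-620 cells (Homo sapiens) for cytotoxicity, read by MTT assay, with a stated time of 48 h (a lower number here means a stronger inhibitor, a higher number a weaker inhibitor), compound 1 gives 15200 nM, and compound 2 gives 18400 nM. The change between them, (thiophen-2-yl in place of 4-methylphenyl on a sulfonyl sulfur), made the step of a 1.2-fold higher number from compound 1 to compound 2 (0.08 log units; within the scatter). Compound 3 gives 32500 nM; its core differs from that of compound 1 by butyl in place of hydrogen on a saturated chain carbon, ten or more bonds along the chain from an amide-type nitrogen, and the step of a 2.1-fold higher number from compound 1 to compound 3 (0.33 log units; beyond the scatter) is modest. Compound 3 stands highest of the three numbers, though its gap to compound 2 lies within the scatter.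

Compound 4 relates to compound 3 exactly as compound 2 relates to compound 1: thiophen-2-yl in place of 4-methylphenyl on a sulfonyl sulfur. This is the same change, at the same place, seen twice across the four compounds. Among the measured compounds shown here, the single measured instance of it, from compound 1 to compound 2, did not move the number beyond the scatter, so the step from compound 3 to compound 4 is expected to be similarly small, about a 1.2-fold higher number from compound 3 to compound 4 (0.08 log units; within the scatter) in this assay, resting on the step of a 1.2-fold higher number from compound 1 to compound 2 (0.08 log units; within the scatter). Because compound 3 already gives 32500 nM, compound 4 is estimated at 39000 nM, with a plausible range from 16000 nM to 95000 nM in this assay.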

Compound 4, half-maximal inhibitory concentration: > 200000 nM
Compound 4 gave a limit, no number; the forecaster's own chance of this, stated with the estimate: 20%; middle value at least 5.1-fold (0.70 log units) away from the limit.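

In this assay compound 4 gives > 200000 nM, which is a limit of the assay and not a number. The exchange of 4-methylphenyl for thiophen-2-yl on a sulfonyl sulfur, nearly silent on the tetradecyl core, gives an at least 6.1-fold higher number from compound 3 to compound 4 (0.78 log units; beyond the scatter) on the octadecyl core, so its size does not carry from one core to the other in this series: the same change on two cores in this assay, a 1.2-fold higher number (0.08 log units; within the scatter) from compound 1 to compound 2 and an at least 6.1-fold higher number (0.78 log units; beyond the scatter) from compound 3 to compound 4, at least 5.0-fold (0.70 log units) apart, beyond the scatter of two such steps The chain change likewise depends on the group on the sulfonyl sulfur, with an at least 10-fold higher number from compound 2 to compound 4 (1.03 log units; beyond the scatter), so the two changes do not act independently in these four compounds, although a single set of four compounds with one limit fixes only a lower bound on the gap and shows neither its true size nor any reason for it: the same change on two cores in this assay, a 2.1-fold higher number (0.33 log units; beyond the scatter) from compound 1 to compound 3 and an at least 10-fold higher number (1.03 log units; beyond the scatter) from compound 2 to compound 4, at least 5.0-fold (0.70 log units) apart, beyond the scatter of two such steps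

The compounds shown leave open whether the jump appears gradually with chain length or only when the octadecyl chain meets thiophen-2-yl, a question that a hexadecyl chain carrying either sulfonyl group would address. They also leave open whether the effect belongs to thiophen-2-yl in particular or extends to other groups on the sulfonyl sulfur, such as an unsubstituted phenyl or a furan-2-yl.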